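The source may hold more compounds than are shown below. What is called first, only, known or untested is meant among the compounds shown, and "the series" means these compounds.

Measured so far:
Compound 1, `COc1nc(Cl)nc(C)c1CCO`: > 100000 nM in a functional assay on MCF7 cells (Homo sapiens) for antiproliferative activity, read by MTT assay, with a stated time of 24 h; on this read-out lower numbers stand for stronger inhibition and higher numbers for weaker inhibition
Compound 2, `COc1nc(C)c(CCOC(C)=O)c(OC)n1`: 65000 nM in this assay

Compound 1 sits at the limit of > 100000 nM in this assay, at which 1 of the 2 values shown sits, so its result is a limit rather than a number. Compound 2 therefore stands as the only real number shown in this assay. Compound 3, `COc1nc(Cl)nc(C)c1CCOC(C)=O`, is not yet measured; it differs from compound 2 by chloro in place of methoxy on an aromatic carbon. Among the compounds with values here, no measured pair shows this exchange, so its effect is open. A small shift toward weaker inhibition is expected, about a 1.4-fold higher number from compound 2 to compound 3 (0.14 log units; within the scatter), possibly none beyond the usual scatter. Compound 3 is accordingly estimated at 90000 nM, ranging from 40000 nM to 250000 nM, and may well return only as a limit.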

Compound 3, half-maximal inhibitory concentration: > 100000 nM
Compound 3 was reported as a limit (the forecaster's own chance of this, stated with the estimate: 45%); middle value at least 1.1-fold (0.04 log units) away from the limit.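

Putting chloro in place of methoxy, on the aromatic carbon between two ring nitrogen atoms, gives an at least 1.5-fold higher number from compound 2 to compound 3 (0.18 log units; that floor lies within the scatter), so this change shows no gain in inhibition in this assay. On these data alone, compound 3 gives > 100000 nM, which is a limit and not a number, so the true size of the step remains unknown. The step from compound 1 to compound 3, acetyl in place of hydrogen on an oxygen, cannot be read, because both results are limits: the limit of > 100000 nM in this assay, at which 2 of the 3 values shown sit.

As far as these compounds go, whether chloro truly weakens inhibition here remains open. So does how an amine or a longer alkoxy chain at this position would read in this assay.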